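The compounds below may be only part of what the source reports. "The series", "measured", "known", "first", "only" and "open" are said of these compounds alone.

Measured compounds:
compound 1 `ClCc1ccc(Cn2cnc3c(Cl)ncnc32)cc1`, 12600 nM in a functional assay on HCT-15 cells (Homo sapiens) for cytotoxicity, read by sulforhodamine B assay, with a stated time of 48 h; on this read-out lower numbers stand for stronger inhibition of growth and higher numbers for weaker inhibition of growth
compound 2 `ClCc1ccccc1Cn1cnc2c(Cl)nc(Cl)nc21`, 1200 nM in this assay

Compound 1 stands at the highest of the two numbers; compound 2 gives a lower value, beyond the scatter, but the two compounds differ in more than one place, so only the two values themselves can be compared. Compound 3 `ClCc1ccc(Cn2cnc3c(Cl)nc(Cl)nc32)cc1` is not yet measured. It differs from compound 1 by chloro in place of hydrogen on an aromatic carbon. The step from compound 1 to compound 3 in this assay is expected to be a decrease beyond the scatter, a 4.2-fold lower number from compound 1 to compound 3 (0.62 log units; beyond the scatter). The estimate for compound 3 is 3000 nM, with a range from 1000 nM to 10000 nM.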

Compound 3, concentration for total growth inhibition: 3800 nM
The estimate for compound 3 lay 1.3-fold (0.10 log units) below the measured number, and the stated range covers the measured number.
By their numbers in this assay, from the lowest: compound 2; then compound 3; then compound 1.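

In this assay, among the compounds shown here, chloro in place of hydrogen on an aromatic carbon, between two ring nitrogen atoms, gives a 3.3-fold lower number from compound 1 to compound 3 (0.52 log units; beyond the scatter), the first step that can be read at a single place. The number at this position therefore responds to this change, modestly but beyond the scatter. Nothing at hand explains the step.

On these data alone, whether an amine or a methoxy group on the same carbon would shift the number in the same direction remains open. Also open, as far as these compounds go, is whether the step would hold with the chloromethyl group placed as in compound 2.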